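A few compounds are considered here, and "the series" means these few. Any claim that something is new, unique, unknown or untested is made for them only; others in the source may bear on it.

Working notes on the shared core. Within the data shown here, compound 3 `Cc1ccccc1CNCc1cc(=O)c2c(O)c(O)ccc2o1` is the only member of the set with a number in an ADME assay on Huh-7 cells (Homo sapiens) for cytotoxicity (a lower number here means that less compound is tolerated, a higher number that more compound is tolerated), where compound 3 gives 52200 nM. Compound 1 `O=c1cc(CNCc2ccccc2Br)oc2ccc(O)c(O)c12` sits at a limit of this assay: compound 1 reads > 100000 nM. Compound 2 `O=c1cc(CNCc2ccccc2O)oc2ccc(O)c(O)c12` also sits at a limit of this assay: compound 2 reads > 100000 nM. For the pair compound 1 and compound 2 the two values show only (the limit of > 100000 nM in this assay, at which 2 of the 3 values shown sit), so the step that the two limits leave unreadable from compound 1 to compound 2 has no readable size. The two steps that reach compound 3 are readable only as floors, an at least 1.9-fold lower number from compound 1 to compound 3 (0.28 log units; that floor lies within the scatter) and an at least 1.9-fold lower number from compound 2 to compound 3 (0.28 log units; that floor lies within the scatter); both floors lie within the scatter, so no real difference between 2-methylphenyl and either of the other two aryl groups is established.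

Compound 4 `O=c1cc(CNCc2cccc(F)c2)oc2ccc(O)c(O)c12` has not yet been measured in this assay. The change is 3-fluorophenyl in place of 2-methylphenyl on a saturated chain carbon bound to an amine nitrogen. Among the measured compounds shown here, no measured step covers a fluorinated aryl group, and the two steps away from compound 3 only say that the other two aryl groups are tolerated up to the limit. The expected step is therefore small, a 1.5-fold higher number from compound 3 to compound 4 (0.19 log units; within the scatter), with a fair chance that compound 4 again reaches the limit. Compound 4 is estimated at 80000 nM, within a range of 35000 nM to 200000 nM.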

Compound 4, half-maximal cytotoxic concentration: > 100000 nM
Compound 4 was reported as a limit; the forecaster's own chance of this, stated with the estimate: 45%; middle value at least 1.2-fold (0.09 log units) away from the limit.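

In this assay, the 3-fluorophenyl group, the only fluorinated aryl group in the set, stands with the 2-bromophenyl and 2-hydroxyphenyl groups at a limit and not at a number: the limit of > 100000 nM in this assay, at which 3 of the 4 values shown sit.

Among these compounds, the one readable new step, an at least 1.9-fold higher number from compound 3 to compound 4 (0.28 log units; that floor lies within the scatter), is only a floor, so it establishes no real difference between 3-fluorophenyl and 2-methylphenyl on a saturated chain carbon bound to an amine nitrogen, and compound 3 remains the only compound with a number. The steps to compound 4 from compound 1 and from compound 2 cannot be read, since both ends of each are limits, so the four aryl groups now shown at this place include no step established as beyond the scatter.

Going by these compounds, how far compound 1, compound 2 and compound 4 lie from one another remains unknown, and so does whether the position of the fluorine matters, as a 2-fluorophenyl or 4-fluorophenyl group would test. Also open, on these data alone, is whether anything other than a substituted phenyl ring, such as a pyridine ring, a cyclohexyl group or a longer chain, would bring a clear change in this assay.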